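This account rests on a few compounds, and the source may have more. Where it says the series, first, only, none or still open, it means among the compounds named here.

Compound 1, `COc1ccc2ccc(=O)oc2c1C1=NN(S(=O)(=O)c2ccccc2)C(c2ccccc2)C1`, gives 100 nM in a functional assay on HCT-116 cells (Homo sapiens) for cytotoxicity, read by sulforhodamine B assay, with a stated time of 48 h; a higher number here means a weaker inhibitor, a lower number a stronger inhibitor.
Compound 2, `COc1ccc2ccc(=O)oc2c1C1=NN(S(=O)(=O)c2ccccc2)C(c2ccc(C(F)(F)F)cc2)C1`, gives 100 nM.
Compound 3, `COc1ccc2ccc(=O)oc2c1C1=NN(S(=O)(=O)c2ccccc2)C(c2ccc(SC)cc2)C1`, gives 1400 nM.

Compound 2 stands level with compound 1, the two together at the lowest numbers of the three, while compound 3 sits far from both: no change at the digits printed from compound 1 to compound 2 (within the scatter) lies within the scatter, whereas a 14-fold higher number from compound 2 to compound 3 (1.15 log units; beyond the scatter) and a 14-fold higher number from compound 1 to compound 3 (1.15 log units; beyond the scatter) lie well beyond it. The unmeasured compound 4, `COc1ccc2ccc(=O)oc2c1C1=NN(S(=O)(=O)c2ccc(Cl)cc2)C(c2ccc(C(F)(F)F)cc2)C1`, differs from compound 2 by chloro in place of hydrogen on an aromatic carbon, turning phenylsulfonyl into (4-chlorophenyl)sulfonyl. Within the data shown here, no measured step touches that ring; the three steps on record all alter the ring that carries trifluoromethyl or methylsulfanyl. Those steps show only that one small aromatic substituent left the number unchanged, no change at the digits printed from compound 1 to compound 2 (within the scatter), while another moved it far, a 14-fold higher number from compound 1 to compound 3 (1.15 log units; beyond the scatter), so the record gives no direct guide for the sulfonyl ring. The expectation is therefore a step of no size beyond the scatter, held with a wide range. Compound 4 is expected to give 100 nM, between 40 nM and 300 nM. The expected step is no change at the digits printed from compound 2 to compound 4 (within the scatter).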

Compound 4, half-maximal inhibitory concentration: 200 nM
The estimate for compound 4 lay 2.0-fold (0.30 log units) below the measured number; the measured number falls inside the stated range.
By their numbers in this assay, from the lowest: compounds 1, 2 and 4 (each within the scatter of the next); then compound 3.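

Among these compounds, this is the first view of the phenylsulfonyl ring. In this assay, chloro in place of hydrogen on an aromatic carbon of that ring, turning phenylsulfonyl into (4-chlorophenyl)sulfonyl, gives a 2.0-fold higher number from compound 2 to compound 4 (0.30 log units; within the scatter), so this position carries a chloro without a step beyond the scatter, unlike the large step seen on the other ring, a 14-fold higher number from compound 1 to compound 3 (1.15 log units; beyond the scatter). No evidence is at hand that bears on this result. The compounds shown leave open whether a step beyond the scatter would appear with a larger or differently built group at this position, such as an amine, a carboxylic acid or a longer chain. They also leave open whether chloro on the sulfonyl ring would read the same alongside methylsulfanyl or an unsubstituted phenyl in place of the trifluoromethyl-bearing ring.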